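A few compounds are considered here, and "the series" means these few. Any claim that something is new, unique, unknown or untested is made for them only; others in the source may bear on it.

Measured so far, in an assay on isolated protein for inhibition of DNA nucleotidylexotransferase (Homo sapiens), read by scintillation counting, with a stated time of 10 min; a higher number here means a weaker inhibitor, a lower number a stronger inhibitor:
compound 1 `O=C(/C=C/c1cn(-c2ccc(Cl)cc2)c2ccccc12)CC(=O)C(=O)O` gives 31 uM
compound 2 `O=C(/C=C/c1cn(Cc2ccccc2)c2ccccc12)CC(=O)C(=O)O` gives 7.9 uM
compound 3 `O=C(/C=C/c1cn(Cc2ccc(Cl)cc2)c2ccccc12)CC(=O)C(=O)O` gives 10 uM

Compound 3 stands second highest of the three numbers in this assay. Its nearest neighbour is compound 2: a 1.3-fold higher number from compound 2 to compound 3 (0.10 log units; within the scatter). The gap to compound 1 is wider: a 3.1-fold lower number from compound 1 to compound 3 (0.49 log units; beyond the scatter).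

Compound 4 `CN(C)C(=O)Cn1cc(/C=C/C(=O)CC(=O)C(=O)O)c2ccccc21` is not yet measured. Relative to compound 3 the change is dimethylcarbamoyl in place of 4-chlorophenyl on a saturated chain carbon bound to an aromatic nitrogen.

Two of the measured steps touch the substituent on the aromatic nitrogen: a 3.9-fold lower number from compound 1 to compound 2 (0.59 log units; beyond the scatter) and a 3.1-fold lower number from compound 1 to compound 3 (0.49 log units; beyond the scatter), both a modest move from an aryl directly on the nitrogen to a benzyl. The third, a 1.3-fold higher number from compound 2 to compound 3 (0.10 log units; within the scatter), shows that a chloro on the benzyl ring changes nothing beyond the scatter. For the measured compounds named here, none of them tests exchanging the aromatic ring on the chain carbon for an amide, which is what the step to compound 4 does, so there is no direct precedent; the only guidance is that the chain carbon on the nitrogen is shared by the two lower numbers, and that substitution on the departing ring has not mattered. The expectation in this assay is therefore a small to modest step, more likely towards a higher number than a lower one, with wide uncertainty.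

Compound 4 is expected to give about 20 uM in this assay, within a range of 6 uM to 70 uM. This estimate means an expected 2.0-fold higher number from compound 3 to compound 4 (0.30 log units; within the scatter).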

Compound 4, concentration for 50% inhibition: 8.9 uM
The estimate for compound 4 lay 2.2-fold (0.35 log units) above the measured number, within the range that was stated.
By their numbers in this assay, from the lowest: compounds 2, 4 and 3 (each within the scatter of the next); then compound 1.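

Working notes on the substituent on the saturated chain carbon bound to the aromatic nitrogen: in this assay, the ring-free dimethylcarbamoyl group cannot be told apart from 4-chlorophenyl (a 1.1-fold lower number from compound 3 to compound 4 (0.05 log units; within the scatter)) or from phenyl (a 1.1-fold higher number from compound 2 to compound 4 (0.05 log units; within the scatter)), so an aromatic ring at this place is not required for a number of this size among the compounds shown. Compound 1 remains the outlier whether the comparison partner carries a ring on the chain carbon or an amide, and the replacement of its 4-chlorophenyl by (dimethylcarbamoyl)methyl on the aromatic nitrogen gives a step (a 3.5-fold lower number from compound 1 to compound 4 (0.54 log units; beyond the scatter)) of about the same size as the earlier moves to benzyl and 4-chlorobenzyl. Nothing available explains why such different groups give matching numbers here.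

The compounds shown leave open whether this tolerance extends to a secondary amide, a carboxylic acid or a basic amine in place of the dimethylcarbamoyl group, or to a longer chain carrying the amide. They also leave open how the numbers respond when the aromatic nitrogen carries only hydrogen or a simple methyl group, which would show whether this substituent contributes at all.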